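Removing one methoxy from compound 1

The compounds below may be only part of what the source reports. "The series", "measured", "known", "first", "only" and "open" are said of these compounds alone.

Measured in a functional assay on HCT-116 cells (Homo sapiens) for inhibition, read by MTT assay, with a stated time of 48 h; on this read-out higher numbers stand for weaker inhibition and lower numbers for stronger inhibition:
- compound 1 `C/C=C/C(=O)N(Cc1ccc(OC)c(OC)c1)c1cc(OC)c(OC)c(OC)c1`: 32800 nM
- compound 2 `C/C=C/C=C/C(=O)N(Cc1ccc(OC)c(O)c1)c1cc(OC)c(OC)c(OC)c1`: 180 nM
- compound 3 `COc1ccc(CN(C(=O)CO)c2cc(OC)c(OC)c(OC)c2)cc1O`: 520 nM

Compound 1, at 32800 nM, carries the highest number of the three, far above the values of compound 2 and compound 3. Compound 4 `C/C=C/C(=O)N(Cc1ccc(OC)cc1)c1cc(OC)c(OC)c(OC)c1` differs from it at one place, with hydrogen in place of methoxy on an aromatic carbon, ortho to a methoxy group (hydrogen in place of methoxy on an aromatic carbon). Among the compounds with values here, the only measured single-place step, a 2.9-fold higher number from compound 2 to compound 3 (0.46 log units; beyond the scatter), lies at a carbonyl carbon and does not test this change. It serves only as a rough guide to size, so a modest step toward a lower number in this assay is expected, though with little certainty. The expected change is a 2.7-fold lower number from compound 1 to compound 4 (0.44 log units; beyond the scatter). For compound 4 the estimated value is 12000 nM, within an expected range of 2500 nM to 50000 nM.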

Compound 4, half-maximal inhibitory concentration: 500 nM
For compound 4 the middle estimate is 24-fold (1.38 log units) above the measured one; measured number below the stated range.
By their numbers in this assay, from the lowest: compound 2; then compounds 4 and 3 (each within the scatter of the next); then compound 1.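

In this assay, replacing methoxy with hydrogen on an aromatic carbon, ortho to a methoxy group, gives a 66-fold lower number from compound 1 to compound 4 (1.82 log units; beyond the scatter) and is a large step. Within the data shown here, this is the first single-place step on this ring, since the earlier one, a 2.9-fold higher number from compound 2 to compound 3 (0.46 log units; beyond the scatter), lay at a carbonyl carbon. It shows that the number in this series can depend strongly on this one methoxy.

No data here explain the size of the step. From the compounds shown here alone, whether an amine or a fluorine at this place would behave like hydrogen or like methoxy remains open.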